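A few compounds are considered here, and "the series" means these few. Any claim that something is new, unique, unknown or untested is made for them only; others in the source may bear on it.

Measured compounds:
compound 1, `COC(=O)C1=C(C)N(c2ccccc2)C=CC1c1ccccc1`: -21.5%
compound 2, `COC(=O)C1=C(C)N(c2ccc(OC)cc2)C=C(C)C1c1ccccc1`: -14.7%

Both numbers come from a functional assay for inhibition, using microsomes, tested at 100 ug/mL; on this read-out higher numbers stand for a weaker effect at the one concentration tested and lower numbers for a stronger effect. Compound 2 gives -14.7% in this assay, and compound 1 gives -21.5%; the two values lie within the usual scatter of each other, so the data do not separate them. Compound 3, `COC(=O)C1=C(C)N(c2ccccc2)C=C(C)C1c1ccccc1`, differs from compound 2 in one place: hydrogen in place of methoxy on an aromatic carbon. Going by the values given here, no step between measured compounds of this kind is available, so the size of such a change is unknown here. Compound 3 is expected to give about -17%, somewhere between -35% and 2%. The expected step of a number 2.3 percentage points lower from compound 2 to compound 3 (within the scatter) is thought to stay within the scatter, with no clear direction.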

Compound 3, a percentage reported as activity, at one concentration (the size of the read-out at that concentration, not a potency): -22.7%
For compound 3 the middle estimate is 5.7 percentage points above the measured one; low and high end bracket the measured number.
By their numbers in this assay, from the lowest: compounds 3, 1 and 2 (each within the scatter of the next).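

In this assay, hydrogen in place of methoxy on the aromatic carbon para to a large group gives a number 8 percentage points lower from compound 2 to compound 3 (within the scatter), so this first test of the position does not separate the two groups. Methyl in place of hydrogen on a double-bonded ring carbon gives a number 1.2 percentage points lower from compound 1 to compound 3 (within the scatter), so that single change does not separate its pair either. On these data alone, whether an amine or a carboxylic acid in that aromatic place would give a number beyond the scatter stays open. Nothing at hand offers an explanation for these results.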